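Amide variation on a shared aryl-oxadiazolyl-azetidine core

This account rests on a few compounds, and the source may have more. Where it says the series, first, only, none or still open, it means among the compounds named here.

Measured so far:
compound 1, `O=C(C1CCCO1)N1CC(c2nc(-c3cccc(Cl)c3)no2)C1`, > 10000 nM
compound 2, `Cc1cccc(-c2noc(C3CN(C(=O)C4CCC(C(F)(F)F)CC4)C3)n2)c1`, 1000 nM

In an assay on HEK293 cells for positive allosteric modulation of metabotropic glutamate receptor 5 (Homo sapiens), read by FLIPR (a higher number here means that more compound is needed for the effect, a lower number that less compound is needed), compound 1 gives only a limit, > 10000 nM, so its position is known only as a bound (the limit of > 10000 nM in this assay, at which 1 of the 2 values shown sits). Compound 2 carries a methyl instead of the chlorine on the phenyl and a 4-(trifluoromethyl)cyclohexyl group on the carbonyl; in this assay compound 2 gives 1000 nM. For the measured compounds named here, the two compounds differ in two places, so no single step between them is defined; the numbers show only that compound 2 reaches a measurable value where compound 1 does not.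

Compound 3, `CC1CCN(C(=O)N2CC(c3nc(-c4cccc(Cl)c4)no3)C2)CC1`, is not yet measured. It differs from compound 1 by 4-methylpiperidin-1-yl in place of oxolan-2-yl on a carbonyl carbon, turning the amide into a urea while keeping the chlorophenyl side unchanged. Going by the values given here, since compound 1 sits at a limit, no step from it can be sized; the expectation is a move downward in this assay, toward a measurable value, of about an at least 3.3-fold lower number from compound 1 to compound 3 (0.52 log units; beyond the scatter). For compound 3 the estimate is 3000 nM, within a range of 800 nM to 12000 nM, with a fair chance that only a limit is returned again.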

Compound 3, half-maximal effective concentration: 865 nM
Estimate against measurement, compound 3: 3.5-fold (0.54 log units) above, and the stated range covers the measured number.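

In this assay, the group on the carbonyl carbon decides whether the chlorophenyl compounds reach a measurable value: with the chlorophenyl side held constant, 4-methylpiperidin-1-yl in place of oxolan-2-yl gives an at least 11-fold lower number from compound 1 to compound 3 (1.06 log units; beyond the scatter). For the compounds shown here, this is the only single-place step in the set, and it shows that the chlorophenyl side does not by itself keep a compound from a measurable value, as compound 3 gives 865 nM. The size of the step is a bound and not a measured difference, as compound 1 rests on a limit: the limit of > 10000 nM in this assay, at which 1 of the 3 values shown sits.

The change turns the amide into a urea and replaces the ring in one move, so the compounds shown do not separate the urea link from the ring, the ring size or the methyl; a urea carrying unsubstituted piperidin-1-yl or morpholin-4-yl would bear on that. Going by these compounds alone, compound 2 differs from compound 1 and compound 3 in two places, so no step to it can be read, and the effect of methyl against chlorine on the phenyl stays open.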